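From a cyclohexyl amide to a triazole amide

The source may report more compounds than this note shows. Statements on the series, on what has been measured and on what is new or still open speak of the compounds shown alone.

Measured so far:
compound 1 `O=C(C1CCCCC1)N1CCC(C(=O)N2N=CCC2c2ccccc2)CC1` gives 5.4
compound 2 `O=C(C1CCC1)N1N=CCC1c1ccccc1` gives 4.7

In a physicochemical assay for lipophilicity, read by HPLC, measured as chromatographic lipophilicity, at pH 7.4 (a lower number here means a more polar compound, a higher number a more lipophilic compound), compound 1 stands highest of the two numbers, with compound 2 sitting lower by a gap beyond the usual scatter. Compound 3 `O=C(c1c[nH]nn1)N1CCC(C(=O)N2N=CCC2c2ccccc2)CC1` keeps the core of compound 1 and changes one group:

1H-1,2,3-triazol-4-yl in place of cyclohexyl on a carbonyl carbon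

Among the compounds with values here, no measured pair shows this kind of swap, so the step must be judged from the change alone. A carbon-only ring leaving and an aromatic ring with three nitrogens and a hydrogen-bond donor entering is expected to lower the number in this assay by a large step, well beyond the scatter, estimated as a number 2.40 log units lower from compound 1 to compound 3 (beyond the scatter). Compound 3 is therefore expected at 3, within 2.3 to 3.7.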

Compound 3, distribution coefficient: 2
Compound 3: middle estimate off by 1.00 log units, on the high side; the measured number lies below the stated range.
By their numbers in this assay, from the lowest: compound 3; then compound 2; then compound 1.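

In this assay, placing 1H-1,2,3-triazol-4-yl in place of cyclohexyl on a carbonyl carbon gives a number 3.40 log units lower from compound 1 to compound 3 (beyond the scatter) in a single change. Within the data shown here, this is the first step here between compounds that differ in one place, and it shows that this position alone can shift the number by a large amount while the core of compound 1 stays the same. Nothing available explains the size of this step. Where a phenyl ring, a longer carbon chain, an amine or a carboxylic acid on the same carbonyl carbon would fall remains open. So does whether the nitrogens of the triazole or the loss of the cyclohexyl ring accounts for most of the step.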